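Ethyl to Methoxy on the Shared Core: Microsomal Half-Life

The source may report more compounds than this note shows. Statements on the series, on what has been measured and on what is new or still open speak of the compounds shown alone.

In an in vitro ADME assay on microsomes (Homo sapiens) for metabolic stability (on this read-out higher numbers stand for a longer-lived compound and lower numbers for a shorter-lived compound), the measured compounds give the following:
compound 1 `CCc1nc(NC(CC)CC)c(OC)nc1-c1ccc(Cl)cc1Cl`: 0.583 h
compound 2 `CCc1nc(-c2ccc(OC)cc2C(F)(F)F)c(CC)nc1NC(CC)CC`: 0.2 h
compound 3 `CCC(CC)Nc1nc(OC)c(-c2ccc(Cl)cc2Cl)nc1OC`: 0.267 h

From compound 1 to compound 3 the change is methoxy in place of ethyl on an aromatic carbon and it gives a 2.2-fold lower number from compound 1 to compound 3 (0.34 log units; beyond the scatter). The difference between the cores of compound 1 and compound 2 is not broken down here. In this assay compound 2 gives 0.2 h, and compound 3 sits within the usual scatter of that value, while compound 1 lies beyond it.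

Compound 4 `CCc1nc(NC(CC)CC)c(OC)nc1-c1ccc(OC)cc1C(F)(F)F` differs from compound 2 by methoxy in place of ethyl on an aromatic carbon. This is the same kind of change as that from compound 1 to compound 3, but the surroundings differ: there it sat ortho to a 2,4-dichlorophenyl group, meta to a (pentan-3-yl)amino group and para to a methoxy group, whereas here it sits ortho to a (pentan-3-yl)amino group, meta to a large group and para to an ethyl group.

Going by the values given here, for compound 4 the expected step is a 1.7-fold lower number from compound 2 to compound 4 (0.22 log units; within the scatter), a drop of about the size seen in a 2.2-fold lower number from compound 1 to compound 3 (0.34 log units; beyond the scatter), since only that one example of the change is available and the place differs. The estimated value for compound 4 is therefore 0.12 h, within 0.06 h to 0.3 h.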

Compound 4, half-life: 2 h
Beside the measured number, compound 4's estimate is 17-fold (1.22 log units) below it, and the stated range ends below it.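

In this assay methoxy in place of ethyl on an aromatic carbon gives a 10-fold higher number from compound 2 to compound 4 (1.00 log units; beyond the scatter), so the same change differs in direction and size between the two cores: the same change on two cores in this assay, a 2.2-fold lower number (0.34 log units; beyond the scatter) from compound 1 to compound 3 and a 10-fold higher number (1.00 log units; beyond the scatter) from compound 2 to compound 4, 22-fold (1.34 log units) apart, beyond the scatter of two such steps. Going by these compounds alone, in this series, the result of the change on one core therefore cannot be assumed for another, and the single earlier step was no safe guide to the second. The pairs do not show which difference in surroundings decides the outcome, since the changed carbon is ortho to a (pentan-3-yl)amino group only in the second step, and the aryl group also differs between the pairs.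

The compounds shown leave open whether the reversal follows the place of the change or the aryl group, which would take the same change at both places with one aryl group held fixed. Also open, as far as these compounds go, is how other groups at this carbon behave, such as an amine, a longer chain like propyl or a cyclopropyl ring.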